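Furan and thiophene aryl-pyridines: chlorofuran step in HeLa cytotoxicity

The source may hold more compounds than are shown below. What is called first, only, known or untested is meant among the compounds shown, and "the series" means these compounds.

Measured so far:
compound 1 `Clc1ccc(-c2cc(-c3cccnc3)nc(-c3ccsc3)c2)o1`: > 50000 nM
compound 2 `Clc1ccc(-c2cc(-c3ccoc3)cc(-c3cccs3)n2)cc1`: 5530 nM
compound 3 `Clc1ccc(-c2cc(-c3cccnc3)nc(-c3cccs3)c2)o1`: 14600 nM

In a functional assay on HeLa cells (Homo sapiens) for cytotoxicity, in the presence of a further agent that is not named here (on this read-out higher numbers stand for weaker inhibition and lower numbers for stronger inhibition), compound 1 gives only a limit, > 50000 nM, and not a number. Compound 3 gives 14600 nM in this assay. Compound 2 gives 5530 nM, the lower of the two numbers, with compound 3 the nearest, its number beyond the scatter above that of compound 2.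

For the measured compounds named here, the one step measured so far, an at least 3.4-fold lower number from compound 1 to compound 3 (0.53 log units; beyond the scatter), stands against the limit of compound 1 (the limit of > 50000 nM in this assay, at which 1 of the 3 values shown sits), so its size is a floor, not a point.

Compound 4 `Clc1ccc(-c2cc(-c3ccc(Cl)o3)cc(-c3cccs3)n2)cc1` is compound 2 with 5-chlorofuran-2-yl in place of furan-3-yl on an aromatic carbon. Going by the values given here, no measured step carries this change directly; the only step seen, from compound 1 to compound 3, also moves a five-membered ring from its 3-yl to its 2-yl attachment and lowered the number at least modestly, which points toward a lower number here too, though the added chlorine on the furan has no precedent. The step of a 2.2-fold lower number from compound 2 to compound 4 (0.34 log units; beyond the scatter) is therefore expected to be modest and downward. Compound 4 is estimated at 2500 nM, with a range from 800 nM to 8000 nM.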

Compound 4, half-maximal inhibitory concentration: 21300 nM
Compound 4: middle estimate off by 8.5-fold (0.93 log units), on the low side; measured number outside the range, above it.
By their numbers in this assay, from the lowest: compound 2; then compounds 3 and 4 (each within the scatter of the next). At a limit, above all of these: compound 1.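

For the compounds shown here, at the place opposite the ring nitrogen, 5-chlorofuran-2-yl in place of furan-3-yl gives a 3.9-fold higher number from compound 2 to compound 4 (0.59 log units; beyond the scatter) in this assay, the first reading of a change at this place and one that runs upward. With 4-chlorophenyl in place of pyridin-3-yl on an aromatic carbon, the step is a 1.5-fold higher number from compound 3 to compound 4 (0.16 log units; within the scatter), so this exchange does not separate the two compounds in this assay. Nothing measured here gives a cause for either step.

Open, as far as these compounds go, is whether the higher number of compound 4 belongs to the chlorine or to the changed attachment of the furan, a question that a plain furan-2-yl at this place would settle. Also open, from the compounds shown here alone, is how an amine or a carboxylic acid in place of that chlorine would read in this assay.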